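Swapping the side group of compound 3

The compounds below may be only part of what the source reports. "The series", "measured", "known", "first", "only" and "open" are said of these compounds alone.

In a functional assay on HL-60 cells (Homo sapiens) for antiproliferative activity, read by MTT assay, with a stated time of 48 h (a higher number here means a weaker inhibitor, a lower number a stronger inhibitor), compound 1 `COC/C1=C/C[C@](C)(CCC=C(C)C)/C=C/[C@@H](OC(=O)C=C(C)C)[C@](C)(O)/C=C/C1=O` reads 3070 nM and compound 3 `CC(C)=CCC[C@]1(C)/C=C/[C@@H](OC(=O)C=C(C)C)[C@](C)(O)/C=C/C(=O)/C(C[Si](C)(C)C(C)(C)C)=C\C1` reads 2770 nM with no real gap between them (a 1.1-fold lower number from compound 1 to compound 3 (0.04 log units; within the scatter)). Compound 2 `CC(C)=CCC[C@]1(C)/C=C/[C@@H](OC(=O)C=C(C)C)[C@](C)(O)/C=C/C(=O)/C(CCl)=C\C1` reads 160 nM and stands far from both, as the step to the silicon-bearing group shows (a 17-fold higher number from compound 2 to compound 3 (1.24 log units; beyond the scatter)). Compound 4 `CO/N=C/C1=C/C[C@](C)(CCC=C(C)C)/C=C/[C@@H](OC(=O)C=C(C)C)[C@](C)(O)/C=C/C1=O` changes the side group of compound 3 (a group of 4 heavy atoms (2 carbon, 1 nitrogen, 1 oxygen; no ring) in place of a group of 8 heavy atoms (7 carbon, 1 silicon; no ring), on a double-bonded ring carbon). The large step on the chloro side (a 19-fold lower number from compound 1 to compound 2 (1.28 log units; beyond the scatter)) brought in chlorine, and the group entering compound 4 holds none. That group contains carbon and oxygen, as the group of compound 1 (3070 nM) does, plus nitrogen. No change beyond the scatter is therefore expected in this assay (a 1.4-fold lower number from compound 3 to compound 4 (0.14 log units; within the scatter)). Compound 4 is estimated at 2000 nM, with an expected range of 500 nM to 6000 nM.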

Compound 4, half-maximal inhibitory concentration: 4760 nM
Compound 4: the middle estimate sits 2.4-fold (0.38 log units) below what was measured, and the stated range covers the measured number.
By their numbers in this assay, from the lowest: compound 2; then compounds 3, 1 and 4 (each within the scatter of the next).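

In this assay, the step to the oxime ether group of compound 4 stays within the scatter on both sides (a 1.7-fold higher number from compound 3 to compound 4 (0.24 log units; within the scatter); a 1.6-fold higher number from compound 1 to compound 4 (0.19 log units; within the scatter)). Three unlike groups on this double-bonded ring carbon thus read alike, and compound 2, with its chloromethyl group, is the one exception (a 30-fold higher number from compound 2 to compound 4 (1.47 log units; beyond the scatter)). Going by these compounds, whether chlorine itself sets compound 2 apart stays open, and a bromomethyl or a hydroxymethyl group in the same place would help to settle it. Nothing available explains the gap.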